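A few compounds are considered here, and "the series" means these few. Any claim that something is new, unique, unknown or untested is made for them only; others in the source may bear on it.

Measured so far:
Compound 1 `COc1cc(C(=O)c2sc(-c3ccc(-c4ccccc4)cc3)cc2N)cc(OC)c1OC` gives > 10000 nM in a functional assay on MOLT-4 cells (Homo sapiens) for antiproliferative activity (on this read-out higher numbers stand for weaker inhibition and lower numbers for stronger inhibition), which is a limit of the assay rather than a number.
Compound 2 `COc1ccc(-c2cc(N)c(C(=O)c3cc(OC)c(OC)c(OC)c3)s2)cc1OC` gives 20 nM in this assay.
Compound 3 `COc1cc(C(=O)c2sc(-c3ccc([N+](=O)[O-])cc3)cc2N)cc(OC)c1OC` gives 110 nM in this assay.

Compound 3 stands highest of the two numbers shown; its nearest neighbour is compound 2, with a 5.5-fold higher number from compound 2 to compound 3 (0.74 log units; beyond the scatter). The step of an at least 90-fold lower number from compound 1 to compound 3 (1.95 log units; beyond the scatter) is large, though compound 1 sits at the limit of > 10000 nM in this assay, at which 1 of the 3 values shown sits, so its true size is open. Compound 4 `COc1cc(C(=O)c2sc(-c3cccc([N+](=O)[O-])c3)cc2N)cc(OC)c1OC` differs from compound 3 by 3-nitrophenyl in place of 4-nitrophenyl on an aromatic carbon. Neither measured step moves the nitro group within its ring; both exchange the whole group on that aromatic carbon, so they bear on the change only loosely. No step beyond the scatter is expected in this assay. Compound 4 is estimated at 200 nM, between 50 nM and 800 nM. That estimate means an expected 1.8-fold higher number from compound 3 to compound 4 (0.26 log units; within the scatter).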

Compound 4, half-maximal inhibitory concentration: 7.5 nM
Beside the measured number, compound 4's estimate is 27-fold (1.43 log units) above it; measured number below the stated range.
By their numbers in this assay, from the lowest: compound 4; then compound 2; then compound 3. At a limit, above all of these: compound 1.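

In this assay, moving the nitro group within its ring, with the same atoms throughout, gives a 15-fold lower number from compound 3 to compound 4 (1.17 log units; beyond the scatter) at this aromatic carbon next to the ring sulfur, so its placement on the ring matters as well as its presence. Against 3,4-dimethoxyphenyl, 3-nitrophenyl gives a 2.7-fold lower number from compound 2 to compound 4 (0.43 log units; beyond the scatter) and so reverses the order seen with 4-nitrophenyl. No measurement shown accounts for the difference.

As far as these compounds go, whether the nitro group itself is needed remains open, since an amine or a nitrile in its place on the same ring would test this.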